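From Trifluoromethyl to Trifluoromethoxy in a Growth Inhibitor

The source may hold more compounds than are shown below. What is called first, only, known or untested is meant among the compounds shown, and "the series" means these compounds.

- compound 1 `FC(F)(F)Oc1ccc(-c2ccc(-c3ccc(-c4nc5ccccc5[nH]4)cc3)cc2)cc1`: 100000 nM
- compound 2 `Oc1cccc2[nH]c(-c3ccc(-c4ccc(-c5ccc(C(F)(F)F)cc5)cc4)cc3)nc12`: 3410 nM

In a functional assay on COLO 205 cells (Homo sapiens) for inhibition, read by sulforhodamine B assay (a higher number here means a weaker inhibitor of growth, a lower number a stronger inhibitor of growth), compound 2 gives 3410 nM, the lower of the two numbers, and its gap to compound 1 lies beyond the scatter. The still unmeasured compound 3 `Oc1cccc2[nH]c(-c3ccc(-c4ccc(-c5ccc(OC(F)(F)F)cc5)cc4)cc3)nc12` carries trifluoromethoxy in place of trifluoromethyl on an aromatic carbon. Within the data shown here, no measured pair shows this change, so the expectation is tentative. An estimated step of a 1.2-fold higher number from compound 2 to compound 3 (0.07 log units; within the scatter) is expected, which would stay within the scatter. For compound 3 the expected value is 4000 nM. Its estimated range runs from 1500 nM to 15000 nM.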

Compound 3, concentration for 50% growth inhibition: 8320 nM
Beside the measured number, compound 3's estimate is 2.1-fold (0.32 log units) below it; low and high end bracket the measured number.
By their numbers in this assay, from the lowest: compound 2; then compound 3; then compound 1.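

In this assay, trifluoromethoxy in place of trifluoromethyl on an aromatic carbon, para to a large group, gives a 2.4-fold higher number from compound 2 to compound 3 (0.39 log units; beyond the scatter), so this position responds to the change and trifluoromethyl holds the lower number. Hydroxy in place of hydrogen on an aromatic carbon, now seen alone in one pair, gives a 12-fold lower number from compound 1 to compound 3 (1.08 log units; beyond the scatter), the larger of the two steps. No measurement available here explains either step.

Still open, going by these compounds, is how chlorine or an amine would fare in place of trifluoromethyl at this position. Also open, on these data alone, is whether a methoxy group or an amine could stand in for the hydroxy and keep its gain.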